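The compounds below may be only part of what the source reports. "The series", "measured", "known", "first", "only" and "open" are said of these compounds alone.

Compound 1 `CCOC(=O)Nc1cccc(C(=O)CSC(=S)SCC)c1`: 2000 nM
Compound 2 `CCSC(=S)SCC(=O)c1cc(OC)ccc1OC`: 15800 nM

In a functional assay on HeLa cells (Homo sapiens) for antiproliferative activity, read by resazurin assay (a higher number here means a weaker inhibitor, a lower number a stronger inhibitor), compound 2 has the higher number of the two, and its gap to compound 1 lies beyond the scatter. Compound 3 `CCSC(=S)SCC(=O)c1cccc(OC)c1` differs from compound 2 by hydrogen in place of methoxy on an aromatic carbon. Among the measured compounds shown here, no measured pair shows this change directly. For the measured compounds named here, the only guide is compound 1, which carries no methoxy and gives 2000 nM. A modest shift towards stronger inhibition, slightly beyond the scatter, therefore seems likely. The expected change is a 2.6-fold lower number from compound 2 to compound 3 (0.42 log units; beyond the scatter). For compound 3, the estimated value is 6000 nM, with an expected range of 2000 nM to 18000 nM.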

Compound 3, half-maximal inhibitory concentration: 5010 nM
Estimate against measurement, compound 3: 1.2-fold (0.08 log units) above, within the range that was stated.
By their numbers in this assay, from the lowest: compound 1; then compound 3; then compound 2.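

Among the compounds shown here, removing the methoxy that sits ortho to a group of 9 heavy atoms and para to a methoxy group gives a 3.2-fold lower number from compound 2 to compound 3 (0.50 log units; beyond the scatter) in this assay and provides the first direct reading of this change. Methoxy in place of (ethoxycarbonyl)amino on an aromatic carbon gives a 2.5-fold higher number from compound 1 to compound 3 (0.40 log units; beyond the scatter) and shows that this exchange also matters. Nothing measured here explains either step. Still open, on these data alone, is how an amine or a carboxylic acid on the same aromatic carbon would compare with hydrogen and methoxy. A single pair also cannot show whether this change would act similarly on other compounds.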